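Removing an aromatic fluoro in two matched pairs

This account rests on a few compounds, and the source may have more. Where it says the series, first, only, none or still open, it means among the compounds named here.

Measured compounds:
compound 1 `COc1ccc(/C=N/NC(=O)Nc2ccc(Oc3ccnc4[nH]ccc34)c(F)c2)c(OC)c1OC`: 8970 nM
compound 2 `COc1ccc(/C=N/NC(=O)Nc2ccc(Oc3ccnc4[nH]ccc34)cc2)c(OC)c1OC`: 27600 nM
compound 3 `CN(C)CCn1cccc1/C=N/NC(=O)Nc1ccc(Oc2ccnc3[nH]ccc23)c(F)c1`: 1600 nM

All three were run in a functional assay on PC-3 cells (Homo sapiens) for antiproliferative activity, read by MTT assay, with a stated time of 72 h; a higher number here means a weaker inhibitor, a lower number a stronger inhibitor. Compound 1 gives 8970 nM, compound 2 gives 27600 nM and compound 3 gives 1600 nM, the lowest of the three numbers; its gap to compound 1 and to compound 2 is beyond the scatter in each case. The difference between the core of compound 1 and the core of compound 3 is not broken down here, so nothing is said about what drives that gap.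

Within the first pair, the change is hydrogen in place of fluoro on an aromatic carbon. It gives a 3.1-fold higher number from compound 1 to compound 2 (0.49 log units; beyond the scatter), a modest loss that still exceeds the scatter.

Compound 4 `CN(C)CCn1cccc1/C=N/NC(=O)Nc1ccc(Oc2ccnc3[nH]ccc23)cc1` has not been measured in this assay. It is obtained from compound 3 by hydrogen in place of fluoro on an aromatic carbon. The surroundings of the place are the same word for word as in the first pair, so this is the same change, made a second time in the series.

Among the measured compounds shown here, only one earlier instance exists, so the expectation rests on a single step. For compound 4 the step of a 2.8-fold higher number from compound 3 to compound 4 (0.45 log units; beyond the scatter) is expected to be of similar size because a 3.1-fold higher number from compound 1 to compound 2 (0.49 log units; beyond the scatter), with wider bounds to allow for the different core. Compound 4 is accordingly estimated at 4500 nM, most likely between 2000 nM and 12000 nM.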

Compound 4, half-maximal inhibitory concentration: 3930 nM
Beside the measured number, compound 4's estimate is 1.1-fold (0.06 log units) above it; measured number inside the range.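

In this assay hydrogen in place of fluoro on an aromatic carbon gives a 2.5-fold higher number from compound 3 to compound 4 (0.39 log units; beyond the scatter) on the second core, so the loss seen on the first core recurs in the same direction and at a matching size: the same change on two cores in this assay, a 3.1-fold higher number (0.49 log units; beyond the scatter) from compound 1 to compound 2 and a 2.5-fold higher number (0.39 log units; beyond the scatter) from compound 3 to compound 4, 1.3-fold (0.10 log units) apart, within the scatter of two such steps. Across these two pairs, the change carries from the core of compound 1 to the core of compound 3 as a modest step of much the same size, and the compound with fluoro gives the lower number in both. Two pairs in a single cell assay do not show that the step would hold on any further core or in other cells, and the numbers alone give no reason why removing the fluoro costs activity on either core.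

Only fluoro and hydrogen appear at this place, so the compounds shown leave open how chloro, methyl or methoxy would compare there, and whether any of them would match or exceed fluoro. Also open, going by these compounds, is whether the step would keep its size with a morpholine or a longer chain in place of the dimethylamino chain of compound 3.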